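A few compounds are considered here, and "the series" means these few. Any claim that something is new, unique, unknown or untested is made for them only; others in the source may bear on it.

Measured so far:
compound 1, `CC(=O)Nc1ccc(-c2nnc(C3(c4ccc(Cl)cc4)CCC3)n2C)c(Cl)c1`, 79%
compound 2, `Cn1c(-c2ccc(C(N)=O)cc2Cl)nnc1C1(c2ccc(Cl)cc2)CCC1`, 57%

Both compounds were tested in a functional assay on the whole organism (strain ICR) for inhibition, with Mus musculus as the target, read by scintillation counting, with a stated time of 4 h, at a dose of 10 mg/kg by the oral route; on this read-out higher numbers stand for more inhibition at the one dose given (going by the name of the read-out) and lower numbers for less inhibition. Compound 1 gives 79%, and compound 2 gives 57%, the lower of the two numbers. Among the measured compounds shown here, the only step between them, a number 22 percentage points lower from compound 1 to compound 2 (beyond the scatter), follows from putting carbamoyl in place of acetamido on an aromatic carbon.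

Compound 3, `Cn1c(-c2ccc(-c3cccnc3)cc2Cl)nnc1C1(c2ccc(Cl)cc2)CCC1`, has not yet been measured in this assay. It differs from compound 2 in one place: pyridin-3-yl in place of carbamoyl on an aromatic carbon. For the measured compounds named here, no measured step involves a pyridin-3-yl group, so nothing among the known numbers speaks directly to this change; the one known step concerns a different exchange at the same aromatic carbon. The expectation for compound 3 therefore rests on little, and a wide range is given. Compound 3 is estimated at 55%, within 25% to 85%. That estimate means a step of a number 2 percentage points lower from compound 2 to compound 3 (within the scatter), expected to stay within the usual scatter.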

Compound 3, a percentage reported as inhibition, in the whole organism at one dose (the size of the read-out at that dose, not a potency): 100%
Compound 3: the middle estimate sits 45 percentage points below what was measured, outside the stated range (above it).
By their numbers in this assay, from the lowest: compound 2; then compound 1; then compound 3.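

With an aromatic ring on this carbon, the number in this assay rises: pyridin-3-yl gives a number 43 percentage points higher from compound 2 to compound 3 (beyond the scatter) when it replaces carbamoyl and a number 21 percentage points higher from compound 1 to compound 3 (beyond the scatter) when it replaces acetamido. Among the compounds shown here, until now this carbon had carried only these two groups without a ring, so the earlier compounds could not show that a larger ring with 6 heavy atoms and no hydrogen-bond donor is compatible with a high number at this dose, and here it gives the highest of the three. Nothing available explains this rise.

The compounds shown leave open whether the ring nitrogen of pyridin-3-yl matters, which a phenyl group on this carbon would test. They also leave open how an amine or a carboxylic acid there would compare.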